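This account rests on a few compounds, and the source may have more. Where it says the series, first, only, none or still open, it means among the compounds named here.

Values in a functional assay on BXPC-3 cells (Homo sapiens) for antiproliferative activity, read by MTT assay, with a stated time of 24 h (a higher number here means a weaker inhibitor, a lower number a stronger inhibitor), so far:
- compound 1 `CCn1c(C(=O)NCC(=O)OC)ccc1C(CC)(CC)c1ccc(OCS(=O)(=O)c2ccccc2)c(C)c1` gives 20000 nM
- compound 2 `CCn1c(C(=O)NC2(CO)CC2)ccc1C(CC)(CC)c1ccc(OCS(=O)(=O)c2ccccc2)c(C)c1` gives 45400 nM

Within the data shown here, compound 2 (45400 nM) carries the higher of the two numbers, so it is the weaker inhibitor of this pair, and compound 1 is its only neighbour. The unmeasured compound 3 `CCn1c(C(=O)N[C@H](CO)CCO)ccc1C(CC)(CC)c1ccc(OCS(=O)(=O)c2ccccc2)c(C)c1` differs from it only on the amide-type nitrogen, where 3-hydroxy-1-(hydroxymethyl)propyl stands in place of 1-(hydroxymethyl)cyclopropyl (3-hydroxy-1-(hydroxymethyl)propyl in place of 1-(hydroxymethyl)cyclopropyl on an amide-type nitrogen). The three-membered ring is lost and a defined stereocentre is gained.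

Among the measured compounds shown here, only one measured step bears on this change: a 2.3-fold higher number from compound 1 to compound 2 (0.36 log units; beyond the scatter). It is modest and sits on the same nitrogen. It does not involve the entering group, so it suggests a size but no direction. In this assay, for the measured compounds named here, no step clearly beyond the scatter is expected, although one of similar size in either direction would not be surprising. The expected step, taken from the estimate, is a 1.3-fold lower number from compound 2 to compound 3 (0.11 log units; within the scatter). For compound 3 the estimated value is 35000 nM (range 15000 nM to 80000 nM).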

Compound 3, half-maximal inhibitory concentration: 15900 nM
Compound 3: middle estimate off by 2.2-fold (0.34 log units), on the high side, and the stated range covers the measured number.
By their numbers in this assay, from the lowest: compounds 3 and 1 (each within the scatter of the next); then compound 2.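

In this assay the substituent on the amide-type nitrogen now gives a step in the opposite direction: 3-hydroxy-1-(hydroxymethyl)propyl in place of 1-(hydroxymethyl)cyclopropyl gives a 2.9-fold lower number from compound 2 to compound 3 (0.46 log units; beyond the scatter) and reverses the earlier rise in size at this position. Compound 2 is thus the weakest of the three, with beyond-scatter steps to both of the others, while the two open-chain substituents, (methoxycarbonyl)methyl and 3-hydroxy-1-(hydroxymethyl)propyl, cannot be told apart, with a 1.3-fold lower number from compound 1 to compound 3 (0.10 log units; within the scatter) as their whole difference despite their different end groups. No supporting data are available to account for either step.

The change from compound 2 to compound 3 removes the three-membered ring and adds a hydroxy group and a defined stereocentre all at once, so the compounds shown do not assign the step to any one of these features, and the opposite configuration at that stereocentre remains open. Also open, going by these compounds, is how this position responds to a primary amine or a carboxylic acid at the end of the chain, or to a longer chain.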